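Swapping methoxy for chloro in a two-compound series

The compounds below may be only part of what the source reports. "The series", "measured", "known", "first", "only" and "open" are said of these compounds alone.

Measured so far in a functional assay on U-87MG ATCC cells for antiproliferative activity against U-87 MG (Homo sapiens), read by MTT assay, with a stated time of 48 h (a higher number here means a weaker inhibitor, a lower number a stronger inhibitor), as working data:
- compound 1 `COc1ccc(-c2nc(C)c(C(=O)CSc3nc(N)c(C#N)c(-c4ccc(Cl)cc4)n3)s2)cc1` gives 4540 nM
- compound 2 `COc1ccc(-c2nc(C)c(C(=O)CSc3nc(N)c(C#N)c(-c4ccc(OC)cc4)n3)s2)cc1` gives 1560 nM

Compound 1 holds the higher of the two numbers, so it is the weaker inhibitor of this pair. The next compound to be read is compound 3 `Cc1nc(-c2ccc(Cl)cc2)sc1C(=O)CSc1nc(N)c(C#N)c(-c2ccc(Cl)cc2)n1` and it has not yet been measured. The change is chloro in place of methoxy on an aromatic carbon with chloro in place of methoxy on an aromatic carbon, para to a large group, that is 4-methoxyphenyl to 4-chlorophenyl.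

For the measured compounds named here, the only measured step bearing on this is a 2.9-fold lower number from compound 1 to compound 2 (0.46 log units; beyond the scatter) and it is modest. That step put methoxy in place of chloro, while the new change runs the opposite way at the other substituted position of compound 1. One step at a different place gives only weak guidance, so a slight lean towards a higher number is expected. The estimated step is a 1.3-fold higher number from compound 1 to compound 3 (0.12 log units; within the scatter) and no change beyond the scatter is expected. Compound 3 is expected at 6000 nM with an estimated range from 2400 nM to 15000 nM in this series.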

Compound 3, half-maximal inhibitory concentration: 3420 nM
Compound 3: middle estimate off by 1.8-fold (0.24 log units), on the high side; the range from low to high includes it.
By their numbers in this assay, from the lowest: compound 2; then compounds 3 and 1 (each within the scatter of the next).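

In this assay, chloro in place of methoxy on the 4-methoxyphenyl group gives a 1.3-fold lower number from compound 1 to compound 3 (0.12 log units; within the scatter), so this position shows no change beyond the scatter for this exchange. The other position, where methoxy replaces chloro, gave a 2.9-fold lower number from compound 1 to compound 2 (0.46 log units; beyond the scatter), which lies beyond the scatter, so the same two groups do not read alike at the two places, although a single step at each cannot establish a general pattern. No measured evidence is available to explain this difference between the two positions.

As far as these compounds go, whether an amine, a carboxylic acid or a longer alkoxy chain in place of chloro at this position would move the number beyond the scatter remains open. The compounds shown also do not settle whether the two positions act independently of each other.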